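Dihydroxyphenyl for dimethoxyphenyl on two cores

The compounds below may be only part of what the source reports. "The series", "measured", "known", "first", "only" and "open" are said of these compounds alone.

Compound 1 `COc1ccc(Oc2ccc(C(C)C)cc2-c2ccsc2S(=O)(=O)NCCNC(=O)Nc2cc(Cl)cc(Cl)c2)cc1OC` and compound 3 `CC(C)c1ccc(Oc2ccc(O)c(O)c2)c(-c2ccsc2S(=O)(=O)NCCNC(=O)Nc2cc(Cl)cc(Cl)c2)c1` share one core; compound 2 `COc1ccc(Oc2ccccc2-c2ccsc2S(=O)(=O)N2CCN(C(=O)Nc3ccc([N+](=O)[O-])cc3)CC2)cc1OC` and compound 4 `O=C(Nc1ccc([N+](=O)[O-])cc1)N1CCN(S(=O)(=O)c2sccc2-c2ccccc2Oc2ccc(O)c(O)c2)CC1` share another, and the difference between the two cores is not broken down here. In a functional assay on HL-60 cells (Homo sapiens) for inhibition, read by CCK-8 assay, with a stated time of 48 h (a higher number here means a weaker inhibitor, a lower number a stronger inhibitor), compound 1 gives 6500 nM and compound 3 gives 6500 nM. The change from compound 1 to compound 3 is 3,4-dihydroxyphenyl in place of 3,4-dimethoxyphenyl on an oxygen on an aromatic ring and makes the step of no change at the digits printed from compound 1 to compound 3 (within the scatter). For compound 2 only a limit is known in this assay, namely > 50000 nM (the limit of > 50000 nM in this assay, at which 1 of the 3 values shown sits). The change from compound 2 to compound 4 is 3,4-dihydroxyphenyl in place of 3,4-dimethoxyphenyl on an oxygen on an aromatic ring, the same change at the same place. Because the step of no change at the digits printed from compound 1 to compound 3 (within the scatter) is flat, the expected step is a step that the limit leaves unreadable from compound 2 to compound 4. Compound 4 is therefore estimated at 60000 nM, between 25000 nM and 150000 nM, and is expected most likely to come back as a limit again.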

Compound 4, half-maximal inhibitory concentration: 4900 nM
For compound 4 the middle estimate is 12-fold (1.09 log units) above the measured one; the whole stated range lies above it.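

In this assay, 3,4-dihydroxyphenyl in place of 3,4-dimethoxyphenyl gives an at least 10-fold lower number from compound 2 to compound 4 (1.00 log units; beyond the scatter), so the change does not carry over at one size from the core of compound 1 to the core of compound 2: the same change on two cores in this assay, no change at the digits printed (within the scatter) from compound 1 to compound 3 and an at least 10-fold lower number (1.00 log units; beyond the scatter) from compound 2 to compound 4, at least 10-fold (1.00 log units) apart, beyond the scatter of two such steps. As far as these compounds go, compound 2 stands at > 50000 nM, which is a limit and not a number, so the full size of that step stays unknown: the limit of > 50000 nM in this assay, at which 1 of the 4 values shown sits. The two cores differ in more than one place, and these compounds do not show which difference sets the size of the step.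

Still open, from the compounds shown here alone, is how a phenyl ring carrying one hydroxyl and one methoxy would behave on each core. Also open, going by these compounds, is whether a carboxylic acid on that ring would follow either step.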